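The source may report more compounds than this note shows. Statements on the series, on what has been measured and on what is new or still open speak of the compounds shown alone.

Measured compounds:
Compound 1 `Cc1cc(C)cc(S(=O)(=O)c2c(C(=O)NC(C)C(=O)NC(C)c3ccncc3)[nH]c3ccc(Cl)cc23)c1` gives 21900 nM in an ADME assay on MT4 cells (Homo sapiens) for cytotoxicity, read by MTT assay; a lower number here means that less compound is tolerated, a higher number that more compound is tolerated.
Compound 2 `Cc1cc(C)cc(S(=O)(=O)c2c(C(=O)NCC(=O)NC(C)c3ccccc3)[nH]c3ccc(Cl)cc23)c1` gives 29400 nM in this assay.

Compound 2 and compound 1 share a common core and differ in the chain that carries the terminal aromatic group. On the two numbers shown, compound 2 gives 29400 nM, and the value of compound 1 lies within the usual scatter of it, so the two compounds cannot be told apart in this assay.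

Compound 3 `Cc1cc(C)cc(S(=O)(=O)c2c(C(=O)NCc3ccc4nc(N)[nH]c4c3)[nH]c3ccc(Cl)cc23)c1` has not yet been measured. It differs from compound 2 in one place (2-amino-1H-benzimidazol-6-yl in place of (1-phenylethyl)carbamoyl on a saturated chain carbon bound to an amide-type nitrogen). Going by the values given here, no step between measured compounds is available for a change of this kind, so the expectation rests only on the two values given and on the nature of the change.

For compound 3 a step of a 1.2-fold lower number from compound 2 to compound 3 (0.07 log units; within the scatter) is expected, that is, none beyond the scatter in either direction. Compound 3 is therefore estimated to give 25000 nM in this assay, with a range from 10000 nM to 60000 nM.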

Compound 3, half-maximal cytotoxic concentration: 5890 nM
For compound 3 the middle estimate is 4.2-fold (0.63 log units) above the measured one, outside the stated range (below it).
By their numbers in this assay, from the lowest: compound 3; then compounds 1 and 2 (each within the scatter of the next).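

Going by these compounds alone, at the saturated chain carbon bound to an amide-type nitrogen, the result gives the first step at any position in this assay: replacing (1-phenylethyl)carbamoyl with 2-amino-1H-benzimidazol-6-yl produces a 5.0-fold lower number from compound 2 to compound 3 (0.70 log units; beyond the scatter). This shows that the group at this place can shift the tolerated concentration beyond the scatter, though the step is modest and it moves towards less compound being tolerated. The change alters several things at once, since the entering group brings a five-membered aromatic ring with 2 hetero atoms and removes the carbonyl of the leaving group, and no available evidence accounts for the step.

The compounds shown leave open which part of the entering group goes with the lower number, as only a match with the amine removed from the 2-amino-1H-benzimidazol-6-yl group, or a plain phenyl on the same carbon, would begin to separate these parts. They also leave open whether this step holds for other groups at this place, such as a carboxylic acid or a longer chain ending in an amine.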